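The source may hold more compounds than are shown below. What is called first, only, known or untested is meant among the compounds shown, and "the series" means these compounds.

Measured so far:
- compound 1 `Cc1ccc2c(O)cc(-c3cccc(Cl)c3)nc2n1`: 25.7 nM
- compound 2 `Cc1cccc(-c2cc(O)c3c(C)cc(C)nc3n2)c1`: 17800 nM

In a functional assay on HCT-116 cells (Homo sapiens) for antiproliferative activity (on this read-out lower numbers stand for stronger inhibition of growth and higher numbers for weaker inhibition of growth), compound 1 gives 25.7 nM, whereas compound 2 gives 17800 nM, the higher of the two numbers and far beyond the usual scatter from compound 1. The two compounds differ in more than one place, so their gap cannot be traced to a single change.

Compound 3 `Cc1cc(C)c2c(O)cc(-c3cccc(Cl)c3)nc2n1` has not yet been measured. Compared with compound 2 it carries chloro in place of methyl on an aromatic carbon on an aromatic carbon of a six-membered aromatic ring of carbon only. Compound 3 shares this chloro group with compound 1, which gave 25.7 nM, while its core matches that of compound 2.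

Because compound 1 with the same chloro group reached 25.7 nM, a large drop in number is expected a 22-fold lower number from compound 2 to compound 3 (1.35 log units; beyond the scatter) in this assay. Compound 3 is estimated at 800 nM, with a plausible range from 80 nM to 8000 nM.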

Compound 3, concentration for 50% growth inhibition: 170 nM
Beside the measured number, compound 3's estimate is 4.7-fold (0.67 log units) above it; low and high end bracket the measured number.
By their numbers in this assay, from the lowest: compound 1; then compound 3; then compound 2.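

Compound 3 lets each change be sized on its own. In this assay, chloro in place of methyl on the carbon-only aromatic ring, meta to a large group, gives a large step (a 100-fold lower number from compound 2 to compound 3 (2.02 log units; beyond the scatter)), while methyl in place of hydrogen on an aromatic carbon of the core gives a modest one (a 6.6-fold higher number from compound 1 to compound 3 (0.82 log units; beyond the scatter)), so among these compounds the swap on the carbon-only ring has the larger effect on the number. Nothing available here explains either step.

On these data alone, only chloro and methyl can be compared at this ring position, so it stays open whether a fluoro, a methoxy or an amine there would behave like either of them. As far as these compounds go, it also stays open whether the swap from methyl to chloro would have the same size on the core of compound 1, which lacks the extra methyl.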